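Swapping the fluorophenyl amide for a trifluoromethylphenyl amide

The source may report more compounds than this note shows. Statements on the series, on what has been measured and on what is new or still open speak of the compounds shown alone.

Compound 1 `Cc1ccc(S(=O)(=O)N[C@@H](CC(=O)NC(C)(C)C)C(=O)NCCNC(=O)c2ccccc2F)cc1` gives > 11000 nM in an ADME assay on HepG2 cells (Homo sapiens) for cytotoxicity (a lower number here means that less compound is needed, a higher number that more compound is needed for the effect), which is a limit of the assay and not a number. Compound 2 `Cc1ccc(S(=O)(=O)N[C@@H](CC(=O)NC(C)(C)C)C(=O)NCCNC(=O)c2cc(C)ccc2F)cc1` gives > 11000 nM in this assay, again a limit of the assay. Compound 3 `Cc1ccc(S(=O)(=O)N[C@@H](CC(=O)NC(C)(C)C)C(=O)NCCNC(=O)c2ccccn2)cc1` gives > 11000 nM in this assay, also a limit of the assay.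

Compound 1 thus stands where every measured value of this series stands: at the limit of > 11000 nM in this assay, at which 3 of the 3 values shown sit. Three steps connect the measured compounds. The step that the two limits leave unreadable from compound 1 to compound 2 adds a methyl in place of hydrogen on an aromatic carbon; the step that the two limits leave unreadable from compound 1 to compound 3 puts pyridin-2-yl in place of 2-fluorophenyl on a carbonyl carbon; the step that the two limits leave unreadable from compound 2 to compound 3 puts pyridin-2-yl in place of 2-fluoro-5-methylphenyl on a carbonyl carbon. None of them has a readable size, so none gives a direction.

Compound 4 `Cc1ccc(S(=O)(=O)N[C@@H](CC(=O)NC(C)(C)C)C(=O)NCCNC(=O)c2cccc(C(F)(F)F)c2)cc1` differs from compound 1 in one place: 3-(trifluoromethyl)phenyl in place of 2-fluorophenyl on a carbonyl carbon. The measured steps from compound 1 to compound 2 and from compound 1 to compound 3 touch the same carbonyl-bound aryl group. All three measured compounds, however, sit at the limit. I therefore expect no step beyond the scatter for a step that the limit leaves unreadable from compound 1 to compound 4, and most likely another limit. My estimate for compound 4 is 15000 nM, within a range from 7000 nM to 40000 nM.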

Compound 4, half-maximal effective concentration: > 11000 nM
Compound 4 ended at the assay's limit; the forecaster's own chance of this, stated with the estimate: 80%; the middle value lies beyond the limit too.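

In this assay compound 4 gives > 11000 nM, which is a limit of the assay and not a number. The steps linking compound 4 to compound 1, compound 2 and compound 3 therefore cannot be read, and all four compounds end up together: the limit of > 11000 nM in this assay, at which 4 of the 4 values shown sit. The compounds shown leave open how far apart these four compounds lie in this assay, and whether any group on this carbonyl carbon would give a readable value there.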